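Swapping the chloro for carboxymethyl in a benzimidazole anilide

The source may report more compounds than this note shows. Statements on the series, on what has been measured and on what is new or still open speak of the compounds shown alone.

The set comprises three measured compounds. In an ADME assay on BHK cells (Mesocricetus auratus) for cytotoxicity, read by MTT assay, with a stated time of 96 h (on this read-out lower numbers stand for higher toxicity in this test and higher numbers for lower toxicity in this test), compound 1 `Fc1cccc(F)c1-c1nc2cc(Cl)c(Cl)cc2[nH]1` reaches only the limit of the test, > 100000 nM. Compound 3 `O=C(CN1CCN(c2ccccc2)CC1)Nc1ccc(-c2nc3cc(C(F)(F)F)ccc3[nH]2)cc1` likewise gives only a limit in this assay, > 100000 nM. Within the data shown here, compound 2 `O=C(CCl)Nc1ccc(-c2nc3cc(C(F)(F)F)ccc3[nH]2)cc1` is the one member with a number in this assay, 22000 nM. Among the measured compounds shown here, compound 2 thus stands as the sole compound with a read value, whereas the other two compounds sit at the limit (the limit of > 100000 nM in this assay, at which 2 of the 3 values shown sit).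

Compound 4 `O=C(O)CCC(=O)Nc1ccc(-c2nc3cc(C(F)(F)F)ccc3[nH]2)cc1` has not yet been measured. It differs from compound 2 by carboxymethyl in place of chloro on a saturated chain carbon bound to a carbonyl carbon.

For the measured compounds named here, no step between measured compounds is available to calibrate this change. Given that two of three values sit at the limit (the limit of > 100000 nM in this assay, at which 2 of the 3 values shown sit), the expected step of a 4.5-fold higher number from compound 2 to compound 4 (0.66 log units; beyond the scatter) is toward lower toxicity, likely reaching the limit. Compound 4 is expected at about 100000 nM, with a range from 40000 nM to 200000 nM.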

Compound 4, half-maximal cytotoxic concentration: > 100000 nM
Compound 4 ended at the assay's limit; the forecaster's own chance of this, stated with the estimate: 65%; the middle value lies on the limit itself.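

In this assay, among these compounds, carboxymethyl in place of chloro on a saturated chain carbon bound to a carbonyl carbon gives an at least 4.5-fold higher number from compound 2 to compound 4 (0.65 log units; beyond the scatter), the only step in this set that can be read. Compound 4 gives > 100000 nM, which is a limit and not a number. The full size of the step therefore stays unknown, because the read-out ends at the same point for most of the set: the limit of > 100000 nM in this assay, at which 3 of the 4 values shown sit.

Going by these compounds, only compound 2, with its chloro, has a read value, so it stays open whether every replacement of chloro at this carbon reaches the limit or whether some keep a number. A plain methyl or a hydroxy group on the saturated chain carbon bound to a carbonyl carbon would show whether losing the chloro alone is enough, or whether the carboxylic acid also plays a part.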